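Thienopyrimidine ureas: chlorophenyl position change across two cores

A few compounds are considered here, and "the series" means these few. Any claim that something is new, unique, unknown or untested is made for them only; others in the source may bear on it.

Compound 1 `CN(C)CCNc1nc(-c2ccc(NC(=O)Nc3ccc(Cl)cc3)cc2)nc2ccsc12` carries a 4-chlorophenyl on the urea, and in a functional assay on NCI-H460 cells (Homo sapiens) for cytotoxicity, read by MTT assay, with a stated time of 72 h (on this read-out higher numbers stand for weaker inhibition and lower numbers for stronger inhibition), compound 1 gives 130 nM. Compound 2 `CN(C)CCNc1nc(-c2ccc(NC(=O)Nc3ccccc3Cl)cc2)nc2ccsc12` differs from it by 2-chlorophenyl in place of 4-chlorophenyl on an amide-type nitrogen, and in this assay compound 2 gives 230 nM; the step is a 1.8-fold higher number from compound 1 to compound 2 (0.25 log units; within the scatter). Compound 3 `CCN(CC)CCNc1nc(-c2ccc(NC(=O)Nc3ccc(Cl)cc3)cc2)nc2c(Cl)c(Cl)sc12` shares the urea of compound 1 but sits on a different core; the difference between the two cores is not broken down here. In this assay compound 3 gives 320 nM, the highest of the three numbers, beyond the scatter against compound 1 but within it against compound 2. Compound 4 `CCN(CC)CCNc1nc(-c2ccc(NC(=O)Nc3ccccc3Cl)cc2)nc2c(Cl)c(Cl)sc12` differs from compound 3 by 2-chlorophenyl in place of 4-chlorophenyl on an amide-type nitrogen, the same change, at the same place, as that from compound 1 to compound 2. Within the data shown here, since only one measured instance of this change exists, the expected step is taken from it: a step of a 1.8-fold higher number from compound 3 to compound 4 (0.26 log units; within the scatter) is expected, with wide uncertainty because the single earlier step of a 1.8-fold higher number from compound 1 to compound 2 (0.25 log units; within the scatter) lies within the scatter. Compound 4 is therefore estimated at 580 nM, between 250 nM and 1400 nM.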

Compound 4, half-maximal inhibitory concentration: 460 nM
Estimate against measurement, compound 4: 1.3-fold (0.10 log units) above; measured number inside the range.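

In this assay, 2-chlorophenyl in place of 4-chlorophenyl on the urea gives a 1.4-fold higher number from compound 3 to compound 4 (0.16 log units; within the scatter), and the two cores show no difference in this change that two such steps can resolve: the same change on two cores in this assay, a 1.8-fold higher number (0.25 log units; within the scatter) from compound 1 to compound 2 and a 1.4-fold higher number (0.16 log units; within the scatter) from compound 3 to compound 4, 1.2-fold (0.09 log units) apart, within the scatter of two such steps

The swap therefore carries from the core of compound 1 to the core of compound 3 without any sign that its size depends on the core. Each step lies within the scatter, however, so neither pair separates the two chlorophenyl groups, and the agreement is between two small steps, not a transfer of a demonstrated effect; nor does it show how a change with a larger step would behave on these cores.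

Still open, on these data alone, is whether the same agreement holds when an unsubstituted phenyl or a trifluoromethylphenyl sits on the urea. Also open, as far as these compounds go, is how either core responds when a morpholine replaces the terminal amine of the side chain.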